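Lengthening the ester chain in a flat cytotoxicity series

The source may report more compounds than this note shows. Statements on the series, on what has been measured and on what is new or still open speak of the compounds shown alone.

In a functional assay on LoVo cells (Homo sapiens) for cytotoxicity, read by colorimetric assay and MTT assay (on this read-out lower numbers stand for stronger inhibition and higher numbers for weaker inhibition), compound 1 (`COc1ccc(-c2cc3cccc(OC)c3nc2O)cc1`) gives 10000 nM, and compound 2 (`COc1cc(OC)c2cc(-c3ccc(OCc4ccccc4)cc3)c(O)nc2c1`) gives 10000 nM. Compound 3 (`COc1ccc(-c2cc3c(OC)cc(OC)cc3n(CC(=O)OCc3ccccc3)c2=O)cc1`) stands level with both at 10000 nM. Compound 4 (`COc1ccc(-c2cc3c(OC)cc(OC)cc3n(CCC(=O)OCc3ccccc3)c2=O)cc1`) carries (benzyloxycarbonyl)methyl in place of benzyloxycarbonyl on a saturated chain carbon bound to an aromatic nitrogen. Among the measured compounds shown here, no measured pair here differs in one place only, so this assay offers no direct precedent for this change. The expectation therefore rests on compound 3 at 10000 nM, which shows no separation from the other two. The expected step of no change at the digits printed from compound 3 to compound 4 (within the scatter) is none beyond the scatter, in either direction. For compound 4 the estimate is 10000 nM, with an expected range of 4000 nM to 15000 nM.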

Compound 4, half-maximal inhibitory concentration: 10000 nM
Compound 4: the middle estimate sits on the measured number at the digits printed; the measured number falls inside the stated range.
By their numbers in this assay, from the lowest: compounds 1, 2, 3 and 4 (each within the scatter of the next).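

In this assay (benzyloxycarbonyl)methyl in place of benzyloxycarbonyl on a saturated chain carbon bound to an aromatic nitrogen gives no change at the digits printed from compound 3 to compound 4 (within the scatter) and this is the only pair shown that differs in one place. At this position, lengthening the ester chain by this one step therefore leaves the read-out unmoved. Nothing on hand offers an explanation for this result. On these data alone, whether a carboxylic acid or an amine in place of the benzyl ester moves the read-out stays open. So does the effect of a longer chain at this position.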